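The source may report more compounds than this note shows. Statements on the series, on what has been measured and on what is new or still open speak of the compounds shown alone.

Measured so far:
Compound 1, `Cc1nc(N)sc1CCCN/C(N)=N/C(=O)CCCCC(=O)/N=C(\N)NCCCc1sc(N)nc1C`, gives 0.9.
Compound 2, `Cc1nc(N)sc1CCCN/C(N)=N/C(=O)CCCCCCCCC(=O)/N=C(\N)NCCCc1sc(N)nc1C`, gives 0.79.
Compound 3, `N/C(=N\C(=O)CCCCCCCCC(=O)/N=C(\N)NCCCc1cnc(N)s1)NCCCc1cnc(N)s1`, gives 0.94.

All three were tested in an in vitro functional assay on Sf9 cells for agonist activity at histamine H2 receptor (Cavia porcellus); on this read-out lower numbers stand for smaller maximal responses and higher numbers for larger maximal responses. Compound 2 has the lowest value of the three. Compound 1 sits higher, and that gap is beyond the usual scatter. Compound 3 sits higher still, and that gap is also beyond the scatter. Compound 1 and compound 3 lie within the scatter of each other, so no order can be read between them.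

The step of interest runs from compound 2 to compound 4, `Cc1nc(N)sc1CCCN/C(N)=N/C(=O)CCCCCCCCC(=O)/N=C(\N)NCCCc1c[nH]cn1`, which has not yet been measured in this assay. The change is 1H-imidazol-4-yl in place of 2-amino-4-methyl-1,3-thiazol-5-yl on a saturated chain carbon, three bonds along the chain from an amine nitrogen. Going by the values given here, nothing among the three measured compounds shows a change of this kind, so no measured step points the way. Since all three measured compounds reach a large maximal response, compound 4 is expected to do so as well, and the step from compound 2 to compound 4 is estimated at a number 0.060 higher from compound 2 to compound 4 (within the scatter), which is within the scatter. For compound 4 the expected value in this assay is 0.85, with a range from 0.7 to 1.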

Compound 4, intrinsic activity: the largest response reached, as a fraction of the reference agonist's: 1.01
The estimate for compound 4 lay 0.16 below the measured number; measured number above the stated range.
By their numbers in this assay, from the lowest: compound 2; then compounds 1, 3 and 4 (each within the scatter of the next, the first and the last beyond it).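

In this assay, replacing one 2-amino-4-methyl-1,3-thiazol-5-yl end group with 1H-imidazol-4-yl gives a number 0.22 higher from compound 2 to compound 4 (beyond the scatter) and shows that a change at this one place can shift the maximal response. This place, on a saturated chain carbon, three bonds along the chain from an amine nitrogen, therefore matters even while the other end of the molecule stays the same, and the entering group has fewer heavy atoms and fewer hydrogen-bond acceptors than the group it replaces. Nothing measured here explains the size of this shift.

From the compounds shown here alone, it remains open whether a phenyl ring or a simple amine at this place would give a similar response. Going by these compounds, it is also open whether the same exchange would have a similar effect with a shorter or longer central chain.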